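Methoxy in Place of Fluoro: From Compound 2 to Compound 4

The compounds below may be only part of what the source reports. "The series", "measured", "known", "first", "only" and "open" are said of these compounds alone.

Compound 2 `O=c1ccoc2cc(OCc3cn(Cc4ccc(F)cc4)nn3)ccc12` was tested in a functional assay on A549 cells (Homo sapiens) for cytotoxicity, read by MTT assay, with a stated time of 48 h; on this read-out higher numbers stand for weaker inhibition and lower numbers for stronger inhibition. In this assay compound 2 gives > 100000 nM, which is a limit of the assay rather than a number. Compound 1 `O=c1ccoc2cc(OCc3cn(Cc4cccc(Br)c4)nn3)ccc12` in this assay gives > 100000 nM, also a limit. Compound 3 `C#CCOc1ccc2c(=O)ccoc2c1` in this assay gives > 100000 nM, again a limit. Among the measured compounds shown here, the one step among measured compounds that differ in one place, a step that the two limits leave unreadable from compound 1 to compound 2, has both of its ends at a limit and so cannot be read. Compound 4 `COc1ccc(Cn2cc(COc3ccc4c(=O)ccoc4c3)nn2)cc1` differs from compound 2 by methoxy in place of fluoro on an aromatic carbon. For the measured compounds named here, no measured step bears on this change in a readable way, and the limit of > 100000 nM in this assay, at which 3 of the 3 values shown sit, shows that every value so far sits at the limit. Going by the values given here, compound 4 is therefore expected to stay at that limit as well, with a step that the limit leaves unreadable from compound 2 to compound 4 expected to be no step readable beyond the scatter. Compound 4 is estimated at 150000 nM, in the range 50000 nM to 500000 nM in this assay.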

Compound 4, half-maximal inhibitory concentration: 16500 nM
The estimate for compound 4 lay 9.1-fold (0.96 log units) above the measured number, outside the stated range (below it).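

In this assay, among the compounds shown here, the exchange of fluoro for methoxy on this aromatic carbon, para to a large group, gives an at least 6.0-fold lower number from compound 2 to compound 4 (0.78 log units; beyond the scatter) and is the first readable change. The exchange of 3-bromophenyl for 4-methoxyphenyl likewise gives an at least 6.0-fold lower number from compound 1 to compound 4 (0.78 log units; beyond the scatter) and so sets compound 4 apart from both halogen-bearing compounds. From the compounds shown here alone, since the numbers on the other side of both steps are limits, the true sizes of the steps remain unknown, and compound 4 alone stands clear of the limit: the limit of > 100000 nM in this assay, at which 3 of the 4 values shown sit.

Going by these compounds, whether this response is particular to methoxy, or would also appear with an amine, a hydroxyl or a longer alkoxy chain at this place, stays open. The compounds shown also leave open how methoxy would read elsewhere on this ring.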